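Isopropoxy for chloro: an expected solubility step

The source may hold more compounds than are shown below. What is called first, only, known or untested is meant among the compounds shown, and "the series" means these compounds.

Compound 1 `CC(C)Oc1ccc(C(O)(c2ccc(C(F)(F)F)cc2)c2cccnc2)cc1` gives 1.6 ug/mL
Compound 2 `OC(c1ccc(Cl)cc1)(c1cccnc1)c1ccc(Cl)cc1F` gives 1.6 ug/mL

In a physicochemical assay for solubility, read by nephelometry, measured as kinetic solubility, at pH 6.5 (on this read-out lower numbers stand for lower solubility and higher numbers for higher solubility), compound 2 gives 1.6 ug/mL and stands level with compound 1 , with no difference beyond the usual scatter of repeated measurements. Compound 3 `CC(C)Oc1ccc(C(O)(c2cccnc2)c2ccc(Cl)cc2F)cc1` has not yet been measured. It differs from compound 2 by a single change (isopropoxy in place of chloro on an aromatic carbon) , with isopropoxy in place of chloro on an aromatic carbon, para to a large group. Among the measured compounds shown here, no measured pair shows this change on its own, so its size cannot be read directly. Compound 1 also carries isopropoxy and gives 1.6 ug/mL while sitting level with compound 2 , so no step beyond the scatter is expected in this assay here. The expected step is a 1.1-fold higher number from compound 2 to compound 3 (0.05 log units; within the scatter) in this estimate. For compound 3 the estimated value is 1.8 ug/mL with a likely range from 0.9 ug/mL to 5 ug/mL as its ends.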

Compound 3, solubility: 1.6 ug/mL
Compound 3: the middle estimate sits 1.1-fold (0.05 log units) above what was measured; measured number inside the range.
By their numbers in this assay, from the lowest: compounds 1, 2 and 3 (each within the scatter of the next).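

In this assay, isopropoxy in place of chloro on an aromatic carbon, para to a large group, gives no change at the digits printed from compound 2 to compound 3 (within the scatter). Among the compounds shown here, this is the first pair to show the change on its own, and it shows that at this position four heavy atoms, one of them an oxygen, can replace a single chlorine without moving the read-out beyond the scatter. Nothing available here accounts for this result.

As far as these compounds go, it remains open whether an amine or a carboxylic acid on this same aromatic carbon would also stay level with compound 2. Also open, from the compounds shown here alone, is whether the same swap would give the same result with the other groups on the shared core changed.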